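The source may report more compounds than this note shows. Statements on the series, on what has been measured and on what is new or still open speak of the compounds shown alone.

Compound 1 `Cc1ccc(C(=O)N/C(N)=N\c2ccccc2C(C)C)cc1`: 4360 nM
Compound 2 `N=C(NCCCCc1ccccc1)NC(=O)c1cccc(Cl)c1Cl`: 1480 nM

Of these two compounds, compound 2 gives the lower number in an assay on CHO cells for inhibition of sodium channel protein type 2 subunit alpha (Homo sapiens) (a higher number here means a weaker inhibitor, a lower number a stronger inhibitor), and the gap to compound 1 lies beyond the usual scatter of this assay. Compound 3 `N=C(NCCCCc1ccccc1)NC(=O)c1cccs1` differs from compound 2 in one place: thiophen-2-yl in place of 2,3-dichlorophenyl on a carbonyl carbon. Among the measured compounds shown here, no step of this kind has been measured here, so its size rests on expectation alone. A moderate rise, that is a weaker inhibitor, is expected, the step being a 2.7-fold higher number from compound 2 to compound 3 (0.43 log units; beyond the scatter). Compound 3 is thus estimated at 4000 nM, with a range from 1500 nM to 12000 nM.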

Compound 3, half-maximal inhibitory concentration: 4310 nM
Estimate against measurement, compound 3: 1.1-fold (0.03 log units) below, and the stated range covers the measured number.
By their numbers in this assay, from the lowest: compound 2; then compounds 3 and 1 (each within the scatter of the next).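

Within this assay, thiophen-2-yl in place of 2,3-dichlorophenyl on a carbonyl carbon gives a 2.9-fold higher number from compound 2 to compound 3 (0.46 log units; beyond the scatter), so the group at this carbonyl carbon affects the reading while the rest of the molecule stays the same. The swap changes ring size, removes both chlorines and brings in a sulfur, and this single step cannot separate these changes. Nothing available here explains the step.

A plain phenyl or a 3-chlorophenyl group at this place could show whether the chlorines or the ring itself matter more. Going by these compounds, how a furan-2-yl group would compare also remains open.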